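This account rests on a few compounds, and the source may have more. Where it says the series, first, only, none or still open, it means among the compounds named here.

The measured compounds:

compound 1, `C[C@]1(O)C[C@](c2cccc(C(F)(F)F)c2)([C@H](O)c2ccccn2)C1`, with 33.3 mL/min/kg in an ADME assay on liver for metabolic stability, with Liver microsome (Homo sapiens) as the target, read by LC-MS, using microsomes, with a stated time of 5 h; on this read-out higher numbers stand for fast clearance and lower numbers for slow clearance;
compound 2, `O[C@H](c1ccccn1)[C@]1(c2cccc(C(F)(F)F)c2)C[C@H](O)C1`, with 133 mL/min/kg;
compound 3, `C[C@]1(O)C[C@](c2ccnc(C(F)(F)F)c2)([C@H](O)c2ccccn2)C1`, with 66.7 mL/min/kg.

Compound 4, `O[C@H](c1ccccn1)[C@]1(c2ccnc(C(F)(F)F)c2)C[C@H](O)C1`, has not yet been measured. Compound 2 differs from compound 1 by hydrogen in place of methyl on a saturated ring carbon, and this change gave a 4.0-fold higher number from compound 1 to compound 2 (0.60 log units; beyond the scatter). The difference between the core of compound 1 and the core of compound 3 is not broken down here. Compound 4 differs from compound 3 by hydrogen in place of methyl on a saturated ring carbon, the same change made at the same place in the ring. Among the measured compounds shown here, since the one measured instance of this change moved the number as a 4.0-fold higher number from compound 1 to compound 2 (0.60 log units; beyond the scatter), the step from compound 3 to compound 4 is expected to be of similar size, a 3.6-fold higher number from compound 3 to compound 4 (0.56 log units; beyond the scatter). Compound 4 is therefore estimated to give 240 mL/min/kg, likely between 110 mL/min/kg and 520 mL/min/kg.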

Compound 4, clearance: 33.3 mL/min/kg
The estimate for compound 4 lay 7.2-fold (0.86 log units) above the measured number, outside the stated range (below it).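

In this assay, hydrogen in place of methyl on a saturated ring carbon gave a 2.0-fold lower number from compound 3 to compound 4 (0.30 log units; within the scatter), and the change did not carry over in the same way between the two cores: the same change on two cores in this assay, a 4.0-fold higher number (0.60 log units; beyond the scatter) from compound 1 to compound 2 and a 2.0-fold lower number (0.30 log units; within the scatter) from compound 3 to compound 4, 8.0-fold (0.90 log units) apart, beyond the scatter of two such steps.
The step seen on the core of compound 1 therefore cannot serve as a rule for the core of compound 3. These two pairs do not show why the cores part, nor how the change would run on any further core.

The compounds shown leave open how an amine, a fluorine or a longer chain would read in place of the methyl on this saturated ring carbon. They also leave open how a nitrile would read in place of the trifluoromethyl group on either core.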